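This account rests on a few compounds, and the source may have more. Where it says the series, first, only, none or still open, it means among the compounds named here.

Compound 1: `COc1ccc(-c2[nH]c3ccc(OC)cc3c2/C=C(\C#N)S(=O)(=O)c2ccccc2)cc1`; in a functional assay on SK-MEL-28 cells (Homo sapiens) for cytotoxicity, read by MTT assay, with a stated time of 96 h (a lower number here means that less compound is needed, a higher number that more compound is needed for the effect), compound 1 reaches only a limit of the assay, > 100000 nM.
Compound 2: `N#C/C(=C\c1c(-c2ccccc2)[nH]c2ccccc12)C(=O)c1cccs1`; in this assay compound 2 gives 28000 nM.
Compound 3: `O=C(/C(=C\c1c(-c2ccccc2)[nH]c2ccccc12)C(=O)C(F)(F)F)c1ccco1`; in this assay compound 3 gives 33000 nM.

All three compounds share the same core, an indole bearing a phenyl-type group and a carbon chain that carries a carbonyl. Compound 2 and compound 3 give numbers that lie within the usual scatter of each other, so neither can be called stronger or weaker than the other. The value of compound 1 is a limit and not a number, as the line the limit of > 100000 nM in this assay, at which 1 of the 3 values shown sits, states, so it offers no measured comparison.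

Compound 4, `N#C/C(=C\c1c(-c2ccccc2)[nH]c2ccccc12)C(=O)c1ccc(Cl)cc1`, has not yet been measured. It differs from compound 2 in one place: 4-chlorophenyl in place of thiophen-2-yl on a carbonyl carbon. Going by the values given here, no measured pair in this set shows what such a swap does, so the size of the step is uncertain; a change within the scatter, in either direction, is the most likely outcome. On that basis compound 4 is expected to give about 22000 nM in this assay, with a range from 6000 nM to 80000 nM, which would mean an estimated step of a 1.3-fold lower number from compound 2 to compound 4 (0.10 log units; within the scatter).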

Compound 4, half-maximal effective concentration: 15000 nM
Beside the measured number, compound 4's estimate is 1.5-fold (0.17 log units) above it; measured number inside the range.
By their numbers in this assay, from the lowest: compounds 4, 2 and 3 (each within the scatter of the next, the first and the last beyond it). At a limit, above all of these: compound 1.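

Going by these compounds alone, this is the first measured swap at this place, the carbonyl carbon that carries the ring, and it gives a step in this assay (a 1.9-fold lower number from compound 2 to compound 4 (0.27 log units; within the scatter)). As that step lies within the scatter, compound 2 and compound 4 cannot be put in order, so a six-membered aromatic ring of carbon only, with its chlorine and 7 heavy atoms, stands in for a five-membered sulfur-containing ring of 5 heavy atoms with no change that can be told from scatter. No measured property shown here bears on this step.

Open, as far as these compounds go, is whether an amine or a carboxylic acid on this carbonyl carbon would move the number beyond the scatter. From the compounds shown here alone, whether the chlorine itself matters also stays open, and only a comparison with plain phenyl could settle it.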